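Amino in place of nitro on a quinolone benzimidazole pair

The compounds below may be only part of what the source reports. "The series", "measured", "known", "first", "only" and "open" are said of these compounds alone.

Of the compounds shown here, two sharing one core have been measured in a functional assay on A2780 cells (Homo sapiens) for cytotoxicity, read by MTT assay, with a stated time of 48 h; a lower number here means a stronger inhibitor, a higher number a weaker inhibitor. Compound 1 `CCn1cc(-c2nc3ccccc3s2)c(=O)c2cc(F)c(N3CCN(C)CC3)cc21` gives 114000 nM in this assay. Compound 2 `CCn1cc(-c2nc3ccc([N+](=O)[O-])cc3[nH]2)c(=O)c2cc(F)c(N3CCN(C)CC3)cc21` gives 4700 nM in this assay. Compound 2 therefore stands at the lower of the two numbers, and its nearest neighbour, compound 1, sits well beyond the scatter from it, so compound 2 is the stronger of the pair.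

Compound 3 `CCn1cc(-c2nc3ccc(N)cc3[nH]2)c(=O)c2cc(F)c(N3CCN(C)CC3)cc21` is not yet measured. It differs from compound 2 in one place: amino in place of nitro on an aromatic carbon. The nitro leaves and an amino enters, on an aromatic carbon of a six-membered aromatic ring of carbon only, part of a fused system of two rings, meta to one fused ring and para to the other.

Among the compounds with values here, no measured pair in this set separates these two groups, so the direction of the step rests on compound 2 alone. Compound 3 is expected to be somewhat weaker in this assay, with the step of a 1.9-fold higher number from compound 2 to compound 3 (0.28 log units; within the scatter) estimated at a modest size that may sit at the edge of the scatter. For compound 3 the estimate in this assay is 9000 nM, within a range from 2500 nM to 32000 nM.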

Compound 3, half-maximal inhibitory concentration: > 50000 nM
Compound 3: a limit, no number; the forecaster's own chance of this, stated with the estimate: 10%; at least 5.5-fold (0.74 log units) between middle value and limit.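

In this assay compound 3 gives a limit and not a number: the limit of > 50000 nM in this assay, at which 1 of the 3 values shown sits. Even so, the change can be sized from one side: amino in place of nitro on this aromatic carbon gives an at least 10-fold higher number from compound 2 to compound 3 (1.02 log units; beyond the scatter), so the group held at this place of the shared core matters in this assay, which the earlier compounds could not show because no pair among them differed here alone: the limit of > 50000 nM in this assay, at which 1 of the 3 values shown sits. The step between compound 1 and compound 3 cannot be read, so the limit gives no order between those two compounds, and the gain seen with compound 2 over compound 1 is now tied to a compound that carries the nitro, with its amino counterpart losing that standing.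

As far as these compounds go, how far the true value of compound 3 lies from the limit stays open, and the finding at this place rests on a single pair. A chlorine, a nitrile or an acetamide on the same aromatic carbon would show whether the lower number of compound 2 belongs to the nitro alone or is shared with other groups.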